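A Carboxy Group on the Ethyl Chain of Compound 3

The source may report more compounds than this note shows. Statements on the series, on what has been measured and on what is new or still open speak of the compounds shown alone.

In a functional assay on MKN-45 cells (Homo sapiens) for inhibition, with a stated time of 72 h (a higher number here means a weaker inhibitor, a lower number a stronger inhibitor), compound 1 (`COc1cc(C(=O)c2ccc3cc[nH]c3c2)cc(OC)c1OC`) gives 480 nM and compound 2 (`COc1cc(C(=O)c2cccc3cc[nH]c23)cc(OC)c1OC`) gives 210 nM on the same measure. Compound 3 (`CCn1ccc2cc(C(=O)c3cc(OC)c(OC)c(OC)c3)ccc21`) gives 31 nM as the lowest of the three numbers, beyond the scatter from both others. Compound 4 (`COc1cc(C(=O)c2ccc3c(ccn3CCC(=O)O)c2)cc(OC)c1OC`) carries carboxy in place of hydrogen on a saturated chain carbon, two bonds along the chain from an aromatic nitrogen, which turns ethyl to 2-carboxyethyl (carboxy in place of hydrogen on a saturated chain carbon, two bonds along the chain from an aromatic nitrogen). For the measured compounds named here, no measured compound here carries a carboxy group, so the data offer no direct guide. A large step beyond the scatter is nevertheless expected in this assay toward a higher number and a weaker inhibitor. The estimated step runs a 26-fold higher number from compound 3 to compound 4 (1.41 log units; beyond the scatter) as a rough judgement. For compound 4 the estimated value is 800 nM with an expected range from 150 nM to 5000 nM in this assay.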

Compound 4, half-maximal inhibitory concentration: > 10000 nM
Compound 4: a limit, no number (the forecaster's own chance of this, stated with the estimate: 10%); middle value at least 12-fold (1.09 log units) from the limit.
By their numbers in this assay, from the lowest: compound 3; then compound 2; then compound 1. At a limit, above all of these: compound 4.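

In this assay compound 4 gives > 10000 nM, which is a limit of the assay and not a number. The ethyl chain of compound 3 therefore does not accept every added group, since carboxy in place of hydrogen on a saturated chain carbon is a large change for the worse: an at least 320-fold higher number from compound 3 to compound 4 (2.50 log units; beyond the scatter). From the compounds shown here alone, whether an amide, an amine or a methyl ester on the same chain would cost as much remains open. So does whether carboxymethyl, or a longer chain ending in a carboxylic acid, would behave like 2-carboxyethyl.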